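The source may hold more compounds than are shown below. What is called first, only, known or untested is meant among the compounds shown, and "the series" means these compounds.

Three compounds built on one shared core have numbers in a functional assay on cells (Homo sapiens), read by thymidine incorporation; a lower number here means a stronger inhibitor, a higher number a weaker inhibitor. Compound 1 (`Cc1cc(NCc2cccnc2)n2ncc(Br)c2n1`) gives 1800 nM, and compound 2 (`Clc1ccccc1-c1cc(NCc2cccnc2)n2ncc(Br)c2n1`) gives 500 nM; 500 nM (2 entries). Compound 3 (`CNc1cc(-c2ccccc2Cl)nc2c(Br)cnn12`) gives 1800 nM, which places it level with compound 1 and on the weaker side of compound 2.

Compound 4 (`Clc1ccccc1-c1cc(NCOc2cccnc2)n2ncc(Br)c2n1`) has not yet been measured. Compared with compound 3, it carries (pyridin-3-yl)oxy in place of hydrogen on a saturated chain carbon bound to a nitrogen on an aromatic ring. Cut one bond further out, the same difference reads methyl to ((pyridin-3-yl)oxy)methyl.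

Among the measured compounds shown here, no measured pair isolates this change, so any expectation is indirect and uncertain. For the measured compounds named here, the only guide is compound 2 at 500 nM; 500 nM (2 entries), which also bears a pyridin-3-yl group on that chain carbon, though without the oxygen. On that basis, a modest move toward a lower number is expected in this assay, and no change beyond the scatter cannot be ruled out. The expected step is a 2.3-fold lower number from compound 3 to compound 4 (0.35 log units; beyond the scatter). The estimated value for compound 4 is 800 nM, with an expected range from 250 nM to 2500 nM.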

Compound 4, half-maximal inhibitory concentration: 170 nM
For compound 4 the middle estimate is 4.7-fold (0.67 log units) above the measured one; the measured number lies below the stated range.
By their numbers in this assay, from the lowest: compound 4; then compounds 1 and 3 (each within the scatter of the next).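

In this assay, placing (pyridin-3-yl)oxy on the saturated chain carbon bound to a nitrogen on an aromatic ring gives an 11-fold lower number from compound 3 to compound 4 (1.02 log units; beyond the scatter), a large step that lies beyond the scatter. This shows that the position, which holds only a hydrogen in compound 3, accepts a substituent of this size and that the number falls substantially when it is present. The values of the two compounds that carry a pyridine ring at this carbon also differ, with compound 2, which lacks the oxygen, at 500 nM; 500 nM (2 entries) and compound 4, which has it, at 170 nM. Nothing available explains why the number falls by this much.

The compounds shown leave open whether the nitrogen of the entering ring has any part in the result, a question that a phenoxy group at the same carbon would address. They also leave open how far the chain can be changed, whether by a longer chain between the core and the pyridine ring or by an amine such as morpholine in place of the (pyridin-3-yl)oxy group.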